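Bromo for methoxy: expected half-life of compound 4

This account rests on a few compounds, and the source may have more. Where it says the series, first, only, none or still open, it means among the compounds named here.

Measured compounds in a physicochemical assay for pharmacokinetics; on this read-out lower numbers stand for a shorter-lived compound and higher numbers for a longer-lived compound:
compound 1 `O=C(NCc1cccs1)N1C(=O)c2ccccc2S1(=O)=O` gives 0.365 h
compound 2 `COc1ccc(CNC(=O)N2C(=O)c3ccccc3S2(=O)=O)cc1` gives 0.187 h
compound 3 `O=C(NCc1ccccc1C(F)(F)F)N1C(=O)c2ccccc2S1(=O)=O` gives 0.187 h

Compound 2 sits level with compound 3 at the digits shown, and the two together are the lowest of the three numbers. Within the data shown here, the only step between neighbours is a 2.0-fold lower number from compound 1 to compound 2 (0.29 log units; within the scatter), a change within the scatter. Compound 4 `O=C(NCc1ccc(Br)cc1)N1C(=O)c2ccccc2S1(=O)=O` differs from compound 2 by bromo in place of methoxy on an aromatic carbon. Among the measured compounds shown here, no measured step covers a bromo for methoxy swap on an aromatic carbon of a six-membered aromatic ring of carbon only, so the expectation rests on the small spread of all three numbers. The estimated step is a 1.2-fold higher number from compound 2 to compound 4 (0.07 log units; within the scatter), not beyond the scatter. Compound 4 is therefore expected to give about 0.22 h in this assay, with a range from 0.1 h to 0.45 h.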

Compound 4, half-life: 0.187 h
Compound 4: middle estimate off by 1.2-fold (0.07 log units), on the high side; the range from low to high includes it.
By their numbers in this assay, from the lowest: compounds 2, 3, 4 and 1 (each within the scatter of the next).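

Putting bromo in place of methoxy on this aromatic carbon, para to a large group, gives no change at the digits printed from compound 2 to compound 4 (within the scatter). At this position, a heavy-atom swap with one bromine entering and a methoxy leaving therefore stays within the scatter, and the step of a 2.0-fold lower number from compound 1 to compound 4 (0.29 log units; within the scatter) also stays within it. No available evidence accounts for this result.

Still open, going by these compounds, is whether an amine or a carboxylic acid on this same aromatic carbon would stay as close. The effect of a longer chain in place of the saturated chain carbon is open too.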